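A Benzothiophene Replaces Phenyl on the Sulfonamide Nitrogen Chain

This account rests on a few compounds, and the source may have more. Where it says the series, first, only, none or still open, it means among the compounds named here.

Compound 1, `COc1cc(N(Cc2ccc(Cl)cc2)S(=O)(=O)c2ccc(C)cc2)cc(OC)c1OC`: 14600 nM
Compound 2, `COc1cc(N(Cc2cccc(C)c2)S(=O)(=O)c2ccc(C)cc2)cc(OC)c1OC`: 8580 nM
Compound 3, `COc1cc(N(Cc2ccccc2)S(=O)(=O)c2ccc(C)cc2)cc(OC)c1OC`: 7810 nM

All three were measured in a functional assay on PC-3 cells (Homo sapiens) for inhibition, read by MTT assay, with a stated time of 48 h; on this read-out higher numbers stand for weaker inhibition and lower numbers for stronger inhibition. Compound 3 gives the lowest number of the three, but the steps of a 1.1-fold lower number from compound 2 to compound 3 (0.04 log units; within the scatter) and a 1.9-fold lower number from compound 1 to compound 3 (0.27 log units; within the scatter) both lie within the scatter, so no ordering can be read from them. Compound 4, `COc1cc(N(Cc2csc3ccc(Cl)cc23)S(=O)(=O)c2ccc(C)cc2)cc(OC)c1OC`, differs from compound 3 by 5-chloro-1-benzothiophen-3-yl in place of phenyl on a saturated chain carbon bound to a sulfonamide nitrogen. Going by the values given here, no measured step makes a change of this kind; the steps of a 1.7-fold lower number from compound 1 to compound 2 (0.23 log units; within the scatter), a 1.9-fold lower number from compound 1 to compound 3 (0.27 log units; within the scatter) and a 1.1-fold lower number from compound 2 to compound 3 (0.04 log units; within the scatter) only vary substituents on that phenyl, and all stay within the scatter. On that basis the expected step of a 1.3-fold lower number from compound 3 to compound 4 (0.11 log units; within the scatter) is small, though the uncertainty is wide. Compound 4 is therefore estimated at 6000 nM, in the range 1500 nM to 24000 nM.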

Compound 4, half-maximal inhibitory concentration: 15300 nM
Compound 4: middle estimate off by 2.6-fold (0.41 log units), on the low side, and the stated range covers the measured number.
By their numbers in this assay, from the lowest: compounds 3, 2, 1 and 4 (each within the scatter of the next).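

Going by these compounds alone, until this result, the place on a saturated chain carbon bound to a sulfonamide nitrogen had carried only phenyl and substituted phenyl groups. In this assay, the much larger 5-chloro-1-benzothiophen-3-yl group stays within the scatter of all three (a 2.0-fold higher number from compound 3 to compound 4 (0.29 log units; within the scatter); a 1.8-fold higher number from compound 2 to compound 4 (0.25 log units; within the scatter); a 1.0-fold higher number from compound 1 to compound 4 (0.02 log units; within the scatter)), so this change shows no readable difference. No measurement shown offers an explanation for this result.

The compounds shown leave open whether an amine, a carboxylic acid or a longer chain at this place would give a difference beyond the scatter. They also do not separate the chloro group from the rest of the 5-chloro-1-benzothiophen-3-yl group.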